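The source may report more compounds than this note shows. Statements on the series, on what has been measured and on what is new or still open speak of the compounds shown alone.

Of the compounds shown here, two have so far been measured in an ADME assay on microsomes from liver (Homo sapiens) for metabolic stability, read by LC-MS, with a stated time of 10 min, tested at 0.5 uM; a higher number here means that more of the compound is left, a lower number that less of the compound is left. Compound 1 (`c1ccc2c(c1)CN[C@@H](CN(CC[C@@H]1CCCNC1)[C@H]1CCCc3cccnc31)C2`) gives 75%, and compound 2 (`c1cnc2c(c1)CCC[C@@H]2N(CCCN1CCNCC1)Cc1cc2ccccc2cn1`) gives 66%. These two numbers lie within the usual scatter of repeated measurements, so neither compound can be ranked above the other. Compound 3 (`c1ccc2c(c1)CN[C@@H](CN(CCN1CCNCC1)[C@H]1CCCc3cccnc31)C2`) has not yet been measured in this assay. It keeps the core of compound 1 but has piperazin-1-yl in place of piperidin-3-yl on a saturated chain carbon, two bonds along the chain from an amine nitrogen. Going by the values given here, no measured pair of compounds shows this exchange on its own, so there is no direct precedent for its effect. The only indirect clue is that compound 2, which also carries piperazin-1-yl but has a different core, gives 66%. On that slender basis, a small downward shift that stays within the scatter is expected, and the estimated step is a number 5 percentage points lower from compound 1 to compound 3 (within the scatter). For compound 3 the estimated value is 70%, with an expected range from 55% to 83%.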

Compound 3, percent of the compound remaining: 96%
Estimate against measurement, compound 3: 26 percentage points below; the measured number lies above the stated range.
By their numbers in this assay, from the lowest: compounds 2 and 1 (each within the scatter of the next); then compound 3.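

In this assay, putting piperazin-1-yl in place of piperidin-3-yl on a saturated chain carbon, two bonds along the chain from an amine nitrogen, gives a clear change: a number 21 percentage points higher from compound 1 to compound 3 (beyond the scatter). Going by these compounds alone, the earlier compounds could not show this, since they differ in more than one place and their numbers lie within the scatter, whereas here the core of compound 1 stays the same and only this six-membered non-aromatic ring changes, with 6 heavy atoms in both the leaving and the entering group, so a small exchange at this position is enough to move the number beyond the scatter. Nothing measured here explains the rise.

This single pair cannot separate the second ring nitrogen from the loss of the defined stereocentre that piperidin-3-yl carries, and it cannot tell whether the exchange would have the same effect on another core. It also leaves open how the number would respond at the same position to a morpholin-4-yl ring, which has an oxygen in place of the second ring nitrogen, or to a piperidin-1-yl ring, which has a single ring nitrogen attached to the chain.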